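The source may report more compounds than this note shows. Statements on the series, on what has been measured and on what is new or still open speak of the compounds shown alone.

Measured so far:
compound 1 `Cc1nn(-c2ncnc3nc[nH]c23)c2c1C(OCc1ccccc1F)CC(=O)N2` — 4 nM
compound 2 `Cc1nn(-c2ncnc3nc[nH]c23)c2c1C(OCCn1nccc1C)CC(=O)N2` — 10 nM

In a functional assay on HEK293 cells for agonist activity at G-protein coupled receptor 39 (Homo sapiens), read by scintillation proximity assay and inositol phosphate accumulation, with a stated time of 75 min, in the presence of a further agent that is not named here (on this read-out higher numbers stand for an effect only at larger amounts of compound and lower numbers for an effect already at smaller amounts), compound 2 gives the higher of the two numbers; its nearest neighbour is compound 1, separated by a 2.5-fold higher number from compound 1 to compound 2 (0.40 log units; beyond the scatter). Compound 3 `Cc1nn(-c2ncnc3nc[nH]c23)c2c1C(c1ccc(F)cc1Cl)CC(=O)N2` is not yet measured; relative to compound 2 the change is a group of 8 heavy atoms (6 carbon, 1 fluorine, 1 chlorine; one six-membered aromatic ring of carbon only) in place of a group of 9 heavy atoms (6 carbon, 2 nitrogen, 1 oxygen; one five-membered aromatic ring with 2 hetero atoms), on a saturated ring carbon. Within the data shown here, only the step of a 2.5-fold higher number from compound 1 to compound 2 (0.40 log units; beyond the scatter) bears on this, and it runs toward a lower number when an aromatic ring of carbon only replaces the five-membered aromatic ring with 2 hetero atoms, though here the chain bearing the oxygen is also lost. A modest step to a lower number is therefore expected, a 1.7-fold lower number from compound 2 to compound 3 (0.22 log units; within the scatter). Compound 3 is estimated at 6 nM, range 1.5 nM to 25 nM.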

Compound 3, half-maximal effective concentration: 9 nM
Compound 3: middle estimate off by 1.5-fold (0.18 log units), on the low side; the measured number falls inside the stated range.
By their numbers in this assay, from the lowest: compound 1; then compounds 3 and 2 (each within the scatter of the next).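

In this assay, 2-chloro-4-fluorophenyl placed directly on the saturated ring carbon matches the pyrazole-bearing ether of compound 2 (a 1.1-fold lower number from compound 2 to compound 3 (0.05 log units; within the scatter)) but not the (2-fluorobenzyl)oxy group of compound 1 (a 2.3-fold higher number from compound 1 to compound 3 (0.35 log units; beyond the scatter)). An oxygen-bearing chain on this carbon is therefore not required for a low nanomolar number, as compound 3 lacks one. No evidence on the cause of either step is available.

Going by these compounds, whether an amine or a carboxylic acid is accepted on this ring carbon remains open. So does the separate contribution of the chlorine and the fluorine on the phenyl ring.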